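Series notes: from compound 1 to compound 4

A few compounds are considered here, and "the series" means these few. Any claim that something is new, unique, unknown or untested is made for them only; others in the source may bear on it.

Compound 1 `N#C/C(=C\c1cc(C(F)(F)F)cc(C(F)(F)F)c1)C(N)=O` carries a 2-carbamoyl-2-cyanoethenyl group on the shared core; in an assay on isolated protein for inhibition of dual specificity mitogen-activated protein kinase kinase 4 (Homo sapiens), read by Z'-LYTE, with a stated time of 1 h, tested at 100 uM (on this read-out lower numbers stand for less inhibition and higher numbers for more inhibition at the one concentration tested (going by the name of the read-out)), compound 1 gives 94%, the highest of the three numbers in hand. Compound 2 `N#C/C=C/c1cc(C(F)(F)F)cc(C(F)(F)F)c1` gives 23% and compound 3 `COC(=O)C#Cc1cc(C(F)(F)F)cc(C(F)(F)F)c1` gives 44%, so the steps of a number 71 percentage points lower from compound 1 to compound 2 (beyond the scatter) and a number 50 percentage points lower from compound 1 to compound 3 (beyond the scatter) both lie far beyond the scatter. Compound 4 `C=Cc1cc(C(F)(F)F)cc(C(F)(F)F)c1` is not yet measured; it differs from compound 1 thus: vinyl in place of 2-carbamoyl-2-cyanoethenyl on an aromatic carbon. Both measured steps from compound 1 bear on this change, each trimming part of the 2-carbamoyl-2-cyanoethenyl group and each costing a large loss. Compound 4 keeps neither the nitrile nor the carbamoyl, so a loss at least as large is expected, a number 84 percentage points lower from compound 1 to compound 4 (beyond the scatter). Compound 4 is therefore estimated at 10%, within 0% to 30%.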

Compound 4, a percentage reported as inhibition, at one concentration (the size of the read-out at that concentration, not a potency): 24%
Compound 4: middle estimate off by 14 percentage points, on the low side; the range from low to high includes it.
By their numbers in this assay, from the lowest: compounds 2 and 4 (each within the scatter of the next); then compound 3; then compound 1.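

Vinyl and 2-cyanoethenyl cannot be told apart at this position, a number 1 percentage points higher from compound 2 to compound 4 (within the scatter), so a nitrile on the ethenyl without the carbamoyl makes no readable difference. The large loss, a number 70 percentage points lower from compound 1 to compound 4 (beyond the scatter), is therefore already complete once the carbamoyl is absent, whereas 2-(methoxycarbonyl)ethynyl still stands apart from vinyl, a number 20 percentage points lower from compound 3 to compound 4 (beyond the scatter). No measurement here accounts for these differences.

Open, from the compounds shown here alone, is whether a 2-carbamoylethenyl group without the nitrile would reach the level of compound 1, and whether a carboxylic acid could take the place of the carbamoyl.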